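The source may hold more compounds than are shown below. What is called first, only, known or untested is meant among the compounds shown, and "the series" means these compounds.

Measured so far in a functional assay on MOLT-3 cells (Homo sapiens); a higher number here means a weaker inhibitor, a lower number a stronger inhibitor:
- compound 1, `CCCCSC[C@H](NC(C)=O)C(=O)CCl`: 5600 nM
- compound 2, `CCCCCSC[C@H](NC(C)=O)C(=O)CCl`: 5400 nM
- compound 3, `CCCCCCCCCCCSC[C@H](NC(C)=O)C(=O)CCl`: 3000 nM

Compound 3 gives the lowest of the three numbers in this assay, but its nearest neighbour is compound 2 at a 1.8-fold lower number from compound 2 to compound 3 (0.26 log units; within the scatter) and its furthest is compound 1 at a 1.9-fold lower number from compound 1 to compound 3 (0.27 log units; within the scatter), so neither gap is beyond the scatter, and nothing separates the three compounds with confidence.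

Compound 4, `CCCCCCCCCCCCCCCCCCCCSC[C@H](NC(C)=O)C(=O)CCl`, differs from compound 3 by nonyl in place of hydrogen on a saturated chain carbon, ten or more bonds along the chain from a sulfur. The measured steps that bear on this are the three chain extensions on the same sulfur-linked chain: a 1.0-fold lower number from compound 1 to compound 2 (0.02 log units; within the scatter), a 1.9-fold lower number from compound 1 to compound 3 (0.27 log units; within the scatter) and a 1.8-fold lower number from compound 2 to compound 3 (0.26 log units; within the scatter). All of them are within the scatter; the two longer extensions lean toward lower numbers, the shortest one shows no movement. On that basis the step to compound 4 in this assay is expected to be small, if anything toward a lower number, and not clearly beyond the scatter; the expected step is a 1.4-fold lower number from compound 3 to compound 4 (0.13 log units; within the scatter). For compound 4 the estimate in this assay is 2200 nM, with a range from 800 nM to 6500 nM.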

Compound 4, half-maximal inhibitory concentration: > 100000 nM
Compound 4 was reported as a limit; the forecaster's own chance of this, stated with the estimate: 10%; middle value at least 45-fold (1.65 log units) from the limit.
By their numbers in this assay, from the lowest: compounds 3, 2 and 1 (each within the scatter of the next). At a limit, above all of these: compound 4.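

In this assay, among these compounds, nonyl in place of hydrogen on a saturated chain carbon, ten or more bonds along the chain from a sulfur, gives an at least 33-fold higher number from compound 3 to compound 4 (1.52 log units; beyond the scatter), the only step that lies beyond the scatter. The earlier extensions, such as a 1.9-fold lower number from compound 1 to compound 3 (0.27 log units; within the scatter), showed no separation, so they gave no sign that this chain position has a length at which the read-out in this assay changes sharply; compound 4 shows that it does, and the trend across compounds 1, 2 and 3 cannot be carried forward to this length. Compound 4 is reported only as a limit, so the step is a lower bound and its true size is unknown: the limit of > 100000 nM in this assay, at which 1 of the 4 values shown sits.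

The compounds shown leave open where, between the chain of compound 3 and the chain of compound 4, the number begins to rise, and whether the rise is gradual or abrupt. Also open, as far as these compounds go, is whether a chain as long as that of compound 4, carrying a carboxylic acid or an amine, would return a measurable number in this assay.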